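The source may hold more compounds than are shown below. What is called first, only, known or untested is meant among the compounds shown, and "the series" means these compounds.

Measured compounds:
- compound 1 `CC1(C)Oc2ccc(C#N)cc2[C@@H](/N=C(\NC#N)Nc2ccc(Cl)cc2)[C@@H]1O` gives 1800 nM
- compound 2 `CC1(C)Oc2ccc(C#N)cc2[C@@H](/N=C(\NC#N)Nc2ccccc2)[C@@H]1O` gives 1400 nM; 1300 nM (2 entries)
- compound 3 `CC1(C)Oc2ccc(C#N)cc2[C@@H](/N=C(\NC#N)Nc2ccc(C(F)(F)F)cc2)[C@@H]1O` gives 8100 nM

In a functional assay (aorta) with Rattus norvegicus as the target (on this read-out lower numbers stand for stronger inhibition and higher numbers for weaker inhibition), compound 3 gives 8100 nM as the highest number shown, and the nearest is compound 1 with 1800 nM as its value. For the measured compounds named here, compound 4 `CC(=O)c1cccc(N/C(=N/[C@@H]2c3cc(C#N)ccc3OC(C)(C)[C@H]2O)NC#N)c1` carries 3-acetylphenyl in place of 4-(trifluoromethyl)phenyl on an amine nitrogen as its only change. The closest guide is a single step, a 4.5-fold higher number from compound 1 to compound 3 (0.65 log units; beyond the scatter), where trifluoromethyl replaced chloro. The repeat readings, (the several entries of compound 2 in this assay, 1400 nM; 1300 nM (2 entries)), agree within the scatter. With trifluoromethyl gone, a modest move to a lower number is expected in this assay, and the expected size is a 3.2-fold lower number from compound 3 to compound 4 (0.51 log units; beyond the scatter) as an estimate. Compound 4 is estimated at 2500 nM, within an expected range of 800 nM to 8000 nM.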

Compound 4, half-maximal inhibitory concentration: 8400 nM
The estimate for compound 4 lay 3.4-fold (0.53 log units) below the measured number; measured number outside the range, above it.
By their numbers in this assay, from the lowest: compound 1; then compounds 3 and 4 (each within the scatter of the next).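

In this assay, removing trifluoromethyl does not by itself shift the number at this amine nitrogen, since 3-acetylphenyl and 4-(trifluoromethyl)phenyl read level: a 1.0-fold higher number from compound 3 to compound 4 (0.02 log units; within the scatter). Against 4-chlorophenyl, the 3-acetylphenyl group also reads higher, with a 4.7-fold higher number from compound 1 to compound 4 (0.67 log units; beyond the scatter), so compound 1 now sits below two different replacements. Repeat readings give no sign that these steps are noise: the several entries of compound 2 in this assay, 1400 nM; 1300 nM (2 entries)

The compounds shown leave open whether any substituent on this phenyl ring, such as an amine or a carboxylic acid, would bring the number below that of compound 1.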